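This account rests on a few compounds, and the source may have more. Where it says the series, first, only, none or still open, it means among the compounds named here.

Measured in an assay on cytosol from placenta for inhibition of 17-beta-hydroxysteroid dehydrogenase type 2 (Homo sapiens), read by HPLC, using microsomes, with a stated time of 10 min, in the presence of a further agent that is not named here; a higher number here means a weaker inhibitor, a lower number a stronger inhibitor:
Compound 1 `Cc1cccc(F)c1N(C)C(=O)c1ccc(-c2ccc(O)cc2)o1` gives 3200 nM.
Compound 2 `Cc1ccc(F)cc1N(C)C(=O)c1ccc(-c2ccc(O)cc2)o1` gives 2200 nM.

Among the compounds with values here, compound 2 holds the lower of the two numbers so far, and compound 1 is its only neighbour; the gap between them is within the scatter, so the two cannot be told apart on these measurements. Within the data shown here, the single measured step, a 1.5-fold lower number from compound 1 to compound 2 (0.16 log units; within the scatter), is likewise within the scatter.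

Compound 3 `Cc1cc(F)ccc1N(C)C(=O)c1ccc(-c2ccc(O)cc2)o1` is built from the same atoms as compound 2, joined differently: 4-fluoro-2-methylphenyl in place of 5-fluoro-2-methylphenyl on an amide-type nitrogen. Among the measured compounds shown here, the only step that bears on this change is the one from compound 1 to compound 2, which also shifted the fluorine within the same ring while leaving the rest of the molecule untouched, and it produced no movement beyond the scatter. For the measured compounds named here, there is no further measured pair that speaks to this kind of change. On that basis, compound 3 is expected to show no step beyond the scatter in this assay, the expected step being a 1.0-fold higher number from compound 2 to compound 3 (0.02 log units; within the scatter). Compound 3 is therefore estimated at 2300 nM, with a range from 900 nM to 6000 nM.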

Compound 3, half-maximal inhibitory concentration: 1700 nM
Beside the measured number, compound 3's estimate is 1.4-fold (0.13 log units) above it, within the range that was stated.
By their numbers in this assay, from the lowest: compounds 3, 2 and 1 (each within the scatter of the next).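

In this assay, the change to 4-fluoro-2-methylphenyl on the amide-type nitrogen gives a 1.3-fold lower number from compound 2 to compound 3 (0.11 log units; within the scatter), and the comparison with the 2-fluoro-6-methylphenyl group gives a 1.9-fold lower number from compound 1 to compound 3 (0.27 log units; within the scatter). The earlier compounds shown here offered a single rearrangement of this ring, whereas there are now three arrangements of the same fluorine and methyl substituents, and these measurements cannot tell any of them apart. Nothing measured alongside these compounds accounts for the small differences, so the steps stand as numbers alone.

On these data alone, it remains open whether a chlorine atom or a methoxy group in place of the fluorine, or an amine on the same ring, would move the number beyond the scatter at this place. Within the data shown here, every step so far only rearranges the same atoms, so it is also open whether an ethyl group in place of the methyl on the ring, or a longer chain in place of the saturated chain carbon on the nitrogen, would separate compounds in a way that these three do not.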